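Thiazole in place of pyridine on the piperidine amide

This account rests on a few compounds, and the source may have more. Where it says the series, first, only, none or still open, it means among the compounds named here.

Compound 3 `Cc1ccc(NC(=O)c2ccc(C)c(C(F)(F)F)c2)cc1OC1CCN(C(=O)c2cccnc2)CC1` gives 5470 nM in an ADME assay on BaF3 cells (Mus musculus) for antiproliferative activity (a lower number here means a stronger inhibitor of growth, a higher number a weaker inhibitor of growth), the lowest of the two numbers shown, with compound 2 `Cc1ccc(NC(=O)c2ccc(C)c(C(F)(F)F)c2)cc1OC1CCN(C(=O)c2ccncc2)CC1` giving 6390 nM, a gap that lies within the scatter. Compound 1 `Cc1ccc(NC(=O)c2cccc(C(F)(F)F)c2)cc1OC1CCN(C(=O)c2cccnc2)CC1` reports > 10000 nM, a limit of the assay rather than a number (the limit of > 10000 nM in this assay, at which 1 of the 3 values shown sits). The step of an at least 1.8-fold lower number from compound 1 to compound 3 (0.26 log units; that floor lies within the scatter) introduces a methyl on an aromatic carbon of the benzamide, while the step of a 1.2-fold lower number from compound 2 to compound 3 (0.07 log units; within the scatter) swaps one pyridine isomer for another on the carbonyl carbon of the piperidine amide without a change beyond the scatter.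

Compound 4 `Cc1ccc(NC(=O)c2ccc(C)c(C(F)(F)F)c2)cc1OC1CCN(C(=O)c2cncs2)CC1` differs from compound 3 at that same amide: 1,3-thiazol-5-yl in place of pyridin-3-yl on a carbonyl carbon. Within the data shown here, of the measured steps only the pyridine isomer swap bears on this position, and it was within the scatter; the data give no step that changes ring size or ring type here. He therefore expects for compound 4 a step of a 1.0-fold higher number from compound 3 to compound 4 (0.00 log units; within the scatter), not beyond the scatter. His estimate for compound 4 in this assay is 5500 nM, between 2000 nM and 15000 nM.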

Compound 4, concentration for 50% growth inhibition: > 10000 nM
Compound 4 was reported as a limit; the forecaster's own chance of this, stated with the estimate: 25%; middle value at least 1.8-fold (0.25 log units) away from the limit.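

Compound 4 is the first compound shown with a ring other than a pyridine on this carbonyl carbon, and in this assay compound 4 gives > 10000 nM, a limit of the assay and not a number. Putting 1,3-thiazol-5-yl here gives an at least 1.8-fold higher number from compound 3 to compound 4 (0.26 log units; that floor lies within the scatter), and an at least 1.5-fold higher number from compound 2 to compound 4 (0.19 log units; that floor lies within the scatter). The five-membered ring thus shows no gain over either pyridine, yet both floors lie within the scatter, so a true loss is not established either: the limit of > 10000 nM in this assay, at which 2 of the 4 values shown sit.

Going by these compounds, how far compound 4 lies past that limit stays open. Also open, on these data alone, is whether a plain phenyl ring, or a pyridine carrying an amine or a carboxylic acid, on this carbonyl carbon would give a lower number than compound 3.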